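Cytotoxicity in THP-1 cells: one aryl swap on the core

A few compounds are considered here, and "the series" means these few. Any claim that something is new, unique, unknown or untested is made for them only; others in the source may bear on it.

Compound 1 `Cc1ccccc1-c1cnc(NC(=O)c2ccc(F)cc2)n1C`: > 50000 nM
Compound 2 `COc1ccc(CNC(=O)NC(=O)c2ccc(F)cc2)cc1`: > 50000 nM

In a toxicity assay on THP-1 cells (Homo sapiens) for inhibition (on this read-out higher numbers stand for lower toxicity in this test and lower numbers for higher toxicity in this test), compound 1 gives > 50000 nM, which is a limit of the assay and not a number. In this assay compound 2 gives > 50000 nM, likewise a limit. Going by the values given here, both values sit at the limit of > 50000 nM in this assay, at which 2 of the 2 values shown sit, so compound 1 stands where every measured value stands, and no step between measured compounds is known.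

Compound 3 `Cc1ccc(-c2cnc(NC(=O)c3ccc(F)cc3)n2C)cc1` differs from compound 1 by 4-methylphenyl in place of 2-methylphenyl on an aromatic carbon. The step from compound 1 to compound 3 is expected to be a number no higher from compound 1 to compound 3 (the limit leaves the size open), none beyond the scatter. Compound 3 is estimated at 50000 nM, with a range from 20000 nM to 150000 nM.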

Compound 3, half-maximal cytotoxic concentration: 60000 nM
Estimate against measurement, compound 3: 1.2-fold (0.08 log units) below; the measured number falls inside the stated range.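

No step from compound 1 to compound 3 can be read in this assay, because the value of compound 1 is a limit: the limit of > 50000 nM in this assay, at which 2 of the 3 values shown sit.

As far as these compounds go, whether 4-methylphenyl in place of 2-methylphenyl changes the half-maximal cytotoxic concentration at all remains open.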